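From compound 3 to compound 4: one ring swapped

This account rests on a few compounds, and the source may have more. Where it says the series, first, only, none or still open, it means among the compounds named here.

compound 1 `Cc1ccc(CS(=O)(=O)/C(=C/c2cc(C)cc(C)c2)C(=O)c2ccc(Cl)cc2)cc1` gives 10000 nM
compound 2 `Cc1ccc(S(=O)(=O)/C(=C/c2ccc(Cl)cc2)C(=O)c2ccc(Cl)cc2)cc1` gives 1000 nM
compound 3 `COc1ccc(/C=C(\C(=O)c2ccc(Cl)cc2)S(=O)(=O)c2ccc(C)cc2)cc1O` gives 1000 nM

These numbers come from a functional assay on DU-145 cells (Homo sapiens) for inhibition, read by trypan blue exclusion, with a stated time of 96 h (a higher number here means a weaker inhibitor of growth, a lower number a stronger inhibitor of growth), and they place compound 3 level with compound 2, together the lowest of the three, while compound 1 stands higher, beyond the scatter.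

Compound 4 `Cc1ccc(S(=O)(=O)/C(=C/c2cc(C)cc(C)c2)C(=O)c2ccc(Cl)cc2)cc1` has not yet been measured. It differs from compound 3 in one place, on a double-bonded chain carbon bound to a double-bonded chain carbon, where 3,5-dimethylphenyl stands in place of 3-hydroxy-4-methoxyphenyl: 3,5-dimethylphenyl in place of 3-hydroxy-4-methoxyphenyl on a double-bonded chain carbon bound to a double-bonded chain carbon is the full count of that change.

Among the compounds with values here, one measured step touches this place. It runs no change at the digits printed from compound 2 to compound 3 (within the scatter) and so a change of group here has once left the number where it was, within the scatter. That is a single example. Compound 1 also carries 3,5-dimethylphenyl and gives 10000 nM as its number, but the rest of its structure is not that of compound 4, so it only tilts the expectation slightly upward.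

The expected change is a 1.5-fold higher number from compound 3 to compound 4 (0.18 log units; within the scatter) and no step beyond the scatter is anticipated. Compound 4 is expected at 1500 nM with 500 nM to 5000 nM as the estimated range around it.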

Compound 4, concentration for 50% growth inhibition: 1000 nM
The estimate for compound 4 lay 1.5-fold (0.18 log units) above the measured number; the range from low to high includes it.
By their numbers in this assay, from the lowest: compounds 2, 3 and 4 (each within the scatter of the next); then compound 1.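

In this assay the group on a double-bonded chain carbon bound to a double-bonded chain carbon can now be varied further, with no change at the digits printed from compound 3 to compound 4 (within the scatter) and no change at the digits printed from compound 2 to compound 4 (within the scatter), so 3,5-dimethylphenyl, with 0 hydrogen-bond donors and 0 hydrogen-bond acceptors, sits level with both 3-hydroxy-4-methoxyphenyl and 4-chlorophenyl. The higher number of compound 1 therefore does not go with 3,5-dimethylphenyl, which compound 1 and compound 4 share; they differ only on the sulfonyl sulfur, where 4-methylphenyl in place of 4-methylbenzyl gives a 10-fold lower number from compound 1 to compound 4 (1.00 log units; beyond the scatter), a single pair that makes this the first sign that the sulfonyl sulfur matters more than the ring. Nothing measured here accounts for either result, so these numbers record what happened without giving a reason.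

From the compounds shown here alone, all the rings at the first place are phenyl rings with small groups, so it remains open whether an amine or a carboxylic acid on that ring, or a pyridine ring in its place, would also leave the number unchanged. Within the data shown here, on the sulfonyl sulfur only two groups appear, and a longer chain such as 2-phenylethyl, or a plain methyl, would show whether the number keeps rising or falls back.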